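Thioether substituent change on the core of compound 1

The source may hold more compounds than are shown below. What is called first, only, known or untested is meant among the compounds shown, and "the series" means these compounds.

All three measured compounds were run in an assay on isolated protein for inhibition of aldehyde dehydrogenase 1A1 (Homo sapiens); on this read-out lower numbers stand for stronger inhibition and higher numbers for weaker inhibition:
compound 1 `Cn1ncc2c(=O)n(-c3ccccc3)c(SC(C)(C)c3ccccc3)nc21` gives 1900 nM
compound 2 `Cn1ccc2c(=O)n(-c3ccccc3)c(SCc3cccc(F)c3)nc21` gives 930 nM
compound 3 `O=c1c2cncn2nc(SCc2cccc(F)c2)n1-c1ccccc1` gives 2200 nM

Compound 1 stands second highest of the three numbers. Compound 3 lies nearest, within the scatter, so no order between the two can be claimed. Compound 2 gives the lower number and lies beyond the scatter from compound 1. Among the measured compounds shown here, compounds 2 and 3 carry different cores from compound 1, so no pair differs in one place only, and nothing measured isolates the effect of the group on the sulfur.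

Compound 4 `CC(Sc1nc2c(cnn2C)c(=O)n1-c1ccccc1)c1cccc(O)c1` has not yet been measured in this assay. It differs from compound 1 as follows: a group of 9 heavy atoms (8 carbon, 1 oxygen; one six-membered aromatic ring of carbon only) in place of a group of 9 heavy atoms (9 carbon; one six-membered aromatic ring of carbon only), on a sulfur

For the measured compounds named here, the entering group brings 1 hydrogen-bond donor and 1 hydrogen-bond acceptor where the leaving 1-methyl-1-phenylethyl had none; no measured compound tests such a change. The step of a 1.6-fold lower number from compound 1 to compound 4 (0.20 log units; within the scatter) is expected to be small, toward a lower number but not clearly beyond the scatter. Compound 4 is estimated at 1200 nM, with a range from 400 nM to 3600 nM.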

Compound 4, half-maximal inhibitory concentration: 130 nM
For compound 4 the middle estimate is 9.2-fold (0.97 log units) above the measured one; the measured number lies below the stated range.
By their numbers in this assay, from the lowest: compound 4; then compound 2; then compounds 1 and 3 (each within the scatter of the next).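

On the core of compound 1, the group on the sulfur is a place where the number can move well beyond the scatter: in this assay the change gives a 15-fold lower number from compound 1 to compound 4 (1.16 log units; beyond the scatter) for a group of the same heavy-atom count. The earlier compounds shown here could not show this, since no two of them differed in one place only. Nothing at hand bears on why the number falls.

The change alters the carbon frame of the group and brings in the hydroxyl at once, so the compounds shown do not separate the two. On these data alone, a methoxy group or an amine in place of the hydroxyl would test whether the oxygen's hydrogen goes with the lower number, and whether the step carries over to the cores of compound 2 and compound 3 also stays open.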